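Swapping an amino acid tail for a methoxy group

A few compounds are considered here, and "the series" means these few. Any claim that something is new, unique, unknown or untested is made for them only; others in the source may bear on it.

Of the compounds shown here, two with a shared core have been tested in an assay on a protein complex for inhibition of CDK8/Cyclin C (Homo sapiens), with a stated time of 1 h, tested at 10 uM; a lower number here means less inhibition, a higher number more inhibition at the concentration tested (going by the name of the read-out). Compound 1 `CC(C)[C@@H](NC(=O)/C=C/c1ccncc1-c1ccc2ccccc2c1)C(=O)O` carries a (1-carboxy-2-methylpropyl)amino group on its carbonyl carbon, while compound 2 `COc1ccc(-c2cnccc2/C=C/C(=O)N2CC(OC)C2)cc1OC` differs at several places at once. In this assay compound 1 gives 77%, the lower of the two numbers seen so far. In this assay compound 2 gives 87%; the gap between these two values lies within the usual scatter of such measurements, so the two cannot be ordered. Compound 3 `COC(=O)/C=C/c1ccncc1-c1ccc2ccccc2c1` has not been measured. It differs from compound 1 in one place: methoxy in place of (1-carboxy-2-methylpropyl)amino on a carbonyl carbon. Within the data shown here, no step between two measured compounds isolates this change, so any expectation must rest on compound 1 alone. A change at the carbonyl carbon of this size is expected to shift the inhibition somewhat downward, possibly no further than the scatter. The step of a number 12 percentage points lower from compound 1 to compound 3 (beyond the scatter) is therefore estimated to be small and negative. Compound 3 is expected to give 65%, with a plausible range from 40% to 85%.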

Compound 3, a percentage reported as inhibition, at one concentration (the size of the read-out at that concentration, not a potency): 102%
Compound 3: middle estimate off by 37 percentage points, on the low side, and the stated range ends below it.
By their numbers in this assay, from the lowest: compounds 1 and 2 (each within the scatter of the next); then compound 3.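

In this assay, putting methoxy in place of (1-carboxy-2-methylpropyl)amino on a carbonyl carbon gives a number 25 percentage points higher from compound 1 to compound 3 (beyond the scatter), which shows that the larger group is not needed at this position for inhibition at the concentration tested. The earlier compounds shown here could not show this, since compound 1 and compound 2 differ at several places at once, whereas here a single change removes 8 heavy atoms, 2 hydrogen-bond donors and a defined stereocentre, and the read-out still goes up rather than down. Nothing measured here explains the rise, so the result stands as an observation without a known cause.

The whole group changes in one step, so the compounds shown cannot tell whether the gain comes from losing the carboxylic acid, the branched chain or the amide hydrogen, or from the methoxy group itself. From the compounds shown here alone, a plain methylamino or an ethoxy group on the same carbonyl carbon would help separate these possibilities, and it remains open whether the methoxy change would have a similar effect on the core of compound 2.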